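The source may report more compounds than this note shows. Statements on the series, on what has been measured and on what is new or still open speak of the compounds shown alone.

Of the compounds shown here, two from this series have been tested in a toxicity assay on GES1 cells (Homo sapiens) for inhibition, read by MTT assay, with a stated time of 72 h (on this read-out higher numbers stand for weaker inhibition and lower numbers for stronger inhibition), and both come out at the edge of what the test can report. Compound 1, `C[C@@H]1CCN(c2cc(-c3ccccc3)nc3ncnn23)C[C@@H]1N(C)c1ncnc2[nH]ccc12`, gives > 100000 nM in this assay, which is a limit of the test rather than a number. Compound 2, `C=CCSc1nc2nc(C)cc(N3CC[C@@H](C)[C@@H](N(C)c4ncnc5[nH]ccc45)C3)n2n1`, likewise gives > 100000 nM in this assay, again a limit and not a number. So compound 2 stands only at a limit, and the single other value shown is a limit as well, a fact summed up by the limit of > 100000 nM in this assay, at which 2 of the 2 values shown sit.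

Compound 3, `Cc1cc(N2CC[C@@H](C)[C@@H](N(C)c3ncnc4[nH]ccc34)C2)n2nc(SCCCc3ccccc3)nc2n1`, has not yet been measured in this assay. It differs from compound 2 in one place: phenethyl in place of vinyl on a saturated chain carbon bound to a sulfur. Within the data shown here, no step between two measured compounds is available here, so there is nothing on which to rest a firm prediction of size or direction.

The step from compound 2 to compound 3 in this assay is expected to be an at least 1.4-fold lower number from compound 2 to compound 3 (0.15 log units; that floor lies within the scatter), which means a change that may or may not pass beyond the scatter. For compound 3 in this assay the estimate is 70000 nM, with a range from 15000 nM to 200000 nM, and a fair chance that the test once more reports only a limit.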

Compound 3, half-maximal inhibitory concentration: > 100000 nM
Compound 3: no number, only a limit (the forecaster's own chance of this, stated with the estimate: 50%); middle value at least 1.4-fold (0.15 log units) from the limit.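

In this assay compound 3 gives > 100000 nM, a limit and not a number. Compound 2 also stands only at a limit, so the step between compound 2 and compound 3 cannot be read. The compounds shown leave open whether any change to this series would give a readable number: the limit of > 100000 nM in this assay, at which 3 of the 3 values shown sit.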